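A few compounds are considered here, and "the series" means these few. Any claim that something is new, unique, unknown or untested is made for them only; others in the source may bear on it.

Measured compounds:
Compound 1, `N#C/C=C/c1cc(F)c(Oc2nc(Nc3ccc(C#N)nc3)nc3ccsc23)c(F)c1`, in a toxicity assay on MT4 cells (Homo sapiens) for cytotoxicity, read by MTT assay, with a stated time of 5 days (a higher number here means that more compound is tolerated, a lower number that less compound is tolerated), gives 47500 nM.
Compound 2, `Cc1cc(-c2ccc(F)cc2)cc(C)c1Oc1nc(Nc2ccc(C#N)c(F)c2)nc2ccsc12`, in this assay gives 97300 nM.
Compound 3, `Cc1cc(/C=C/C#N)cc(C)c1Oc1nc(Nc2ccc(C#N)c(F)c2)nc2cc[nH]c12`, in this assay gives 188000 nM.

Compound 3 carries the highest of the three numbers in this assay. Against compound 2 the gap is within the usual scatter, so the two cannot be told apart. Against compound 1 the gap lies beyond the scatter, and compound 1 differs from compound 3 in more than one place, so no single step can be read from that pair.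

Compound 4, `Cc1cc(/C=C/C#N)cc(C)c1Oc1nc(Nc2ccc(C#N)nc2)nc2cc[nH]c12`, has not yet been measured. It differs from compound 3 by 6-cyanopyridin-3-yl in place of 4-cyano-3-fluorophenyl on a nitrogen on an aromatic ring. Among the measured compounds shown here, no measured pair in this set shows this change on its own, so no step is available to rest on. The author expects no step beyond the scatter in this assay, with the number staying in the same region as compound 3. For compound 4 the estimate is 150000 nM, with a range from 60000 nM to 320000 nM, which is expected to amount to a 1.3-fold lower number from compound 3 to compound 4 (0.10 log units; within the scatter).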

Compound 4, half-maximal cytotoxic concentration: 7940 nM
Estimate against measurement, compound 4: 19-fold (1.28 log units) above; measured number below the stated range.
By their numbers in this assay, from the lowest: compound 4; then compound 1; then compounds 2 and 3 (each within the scatter of the next).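

In this assay, among the compounds shown here, 6-cyanopyridin-3-yl in place of 4-cyano-3-fluorophenyl on the nitrogen gives a 24-fold lower number from compound 3 to compound 4 (1.37 log units; beyond the scatter), a large step and the first single change in this set that can be read. It shows that this position is not indifferent: with the rest of compound 3 unchanged, swapping this one group moves the tolerated concentration well beyond the scatter. Nothing shown accounts for the size of this step.

From the compounds shown here alone, the ring nitrogen enters and the fluorine leaves in the same step, so it remains open which of the two goes with the drop; 4-cyanophenyl on the same nitrogen would separate them. Also open, going by these compounds, is whether this exchange gives a step of similar size on another core, and whether an amine in place of the nitrile would behave alike.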